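Ethoxy in place of phenyl on a carbonyl carbon

This account rests on a few compounds, and the source may have more. Where it says the series, first, only, none or still open, it means among the compounds named here.

Working notes on the series in a functional assay on A-375 cells (Homo sapiens) for cytotoxicity, read by MTT assay, with a stated time of 48 h; a higher number here means a weaker inhibitor, a lower number a stronger inhibitor. Within the data shown here, compound 2 `CC1(C)S[C@@H]2/C(=C\C(=O)c3ccccc3)C(=O)N2[C@H]1C(=O)OC(c1ccccc1)c1ccccc1` gives 22800 nM, the lowest of the two numbers so far; compound 1 `CC1(C)[C@H](C(=O)OC(c2ccccc2)c2ccccc2)N2C(=O)/C(=C/C(=O)c3ccc([N+](=O)[O-])cc3)[C@H]2[S+]1[O-]` gives 48200 nM, a gap beyond the scatter. Compound 3 `CCOC(=O)/C=C1/C(=O)N2[C@@H]1SC(C)(C)[C@@H]2C(=O)OC(c1ccccc1)c1ccccc1` is not yet measured; it differs from compound 2 by ethoxy in place of phenyl on a carbonyl carbon. Among the measured compounds shown here, no measured pair shows this change, so its effect is unknown from the data. A modest weakening is expected, with the step of a 1.4-fold higher number from compound 2 to compound 3 (0.15 log units; within the scatter) staying close to the scatter in this assay. For compound 3 a value of 32000 nM is estimated, between 10000 nM and 100000 nM.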

Compound 3, half-maximal inhibitory concentration: 7000 nM
Estimate against measurement, compound 3: 4.6-fold (0.66 log units) above; measured number below the stated range.
By their numbers in this assay, from the lowest: compound 3; then compound 2; then compound 1.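

In this assay, ethoxy in place of phenyl on a carbonyl carbon gives a 3.3-fold lower number from compound 2 to compound 3 (0.51 log units; beyond the scatter) and so strengthens the read-out. This position therefore does not need the six-membered aromatic ring of the benzoyl group for this level of cytotoxicity. No measurement available here accounts for the gain.

Since the ring leaves and the oxygen enters in one change, the compounds shown cannot separate the two. They also leave open whether a longer chain on that oxygen, or a carboxylic acid or an amide at the same carbonyl carbon, would hold this gain.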